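The compounds below may be only part of what the source reports. "The series", "measured", "known", "first", "only" and "open" are said of these compounds alone.

Compound 1, `COC(=O)c1ccc(-c2cnc(C(=O)CCCCCCc3ccccc3)o2)nc1`: in an assay for inhibition of Fatty-acid amide hydrolase 1 (Rattus norvegicus), using a Dixon plot (on this read-out lower numbers stand for stronger inhibition and higher numbers for weaker inhibition), compound 1 gives 3.1 nM.
Compound 2, `O=Cc1ccc(-c2cnc(C(=O)CCCCCCc3ccccc3)o2)nc1`: compound 2 gives 2.2 nM.
Compound 3, `O=C(CCCCCCc1ccccc1)c1ncc(-c2ccc(CO)cn2)o1`: compound 3 gives 3.2 nM.

All three share one core and differ only in the group on the aromatic carbon of the six-membered ring. Compound 2 stands close to both neighbours: a 1.4-fold lower number from compound 1 to compound 2 (0.15 log units; within the scatter), and a 1.5-fold higher number from compound 2 to compound 3 (0.16 log units; within the scatter), so the three numbers cannot be told apart, and compound 1 and compound 3 sit equally close, a 1.0-fold higher number from compound 1 to compound 3 (0.01 log units; within the scatter).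

The next compound, compound 4, `CSCc1ccc(-c2cnc(C(=O)CCCCCCc3ccccc3)o2)nc1`, continues this series. It differs from compound 2 in one place: (methylsulfanyl)methyl in place of formyl on an aromatic carbon. The three measured steps all bear on this change, since each of them also swaps the group on this same aromatic carbon, and each of them stayed within the scatter. Among the compounds with values here, nothing measured so far suggests that the group at this position moves the number. The expected step in this assay is therefore a 1.4-fold higher number from compound 2 to compound 4 (0.13 log units; within the scatter), a change that should not rise beyond the scatter in either direction. Compound 4 is expected to give about 3 nM, with a likely range from 1.2 nM to 8 nM.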

Compound 4, inhibition constant: 11.1 nM
Compound 4: middle estimate off by 3.7-fold (0.57 log units), on the low side; measured number above the stated range.
By their numbers in this assay, from the lowest: compounds 2, 1 and 3 (each within the scatter of the next); then compound 4.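

Compound 4 shows that this position is not indifferent to its group in this assay: replacing formyl with (methylsulfanyl)methyl gives a 5.0-fold higher number from compound 2 to compound 4 (0.70 log units; beyond the scatter) and replacing methoxycarbonyl with it gives a 3.6-fold higher number from compound 1 to compound 4 (0.55 log units; beyond the scatter) while the formyl, methoxycarbonyl and hydroxymethyl compounds remain within the scatter of one another. The closest comparison changes only the end of the small side group, with methylsulfanyl in place of hydroxy on the saturated chain carbon bound to the aromatic carbon, and it still gives a 3.5-fold higher number from compound 3 to compound 4 (0.54 log units; beyond the scatter) so that compound 4 is the weakest inhibitor of the four. No measurement presented here explains why the number rises with this group.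

The compounds shown leave open whether the higher number goes with the sulfur atom itself or with the whole three-atom group, a question that methoxymethyl, with oxygen in place of sulfur, or ethylsulfanylmethyl, with a longer chain, could help to separate. They also leave open whether an aminomethyl group or a carboxylic acid at this position would stay with the first three compounds or move the number as well.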